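The compounds below may be only part of what the source reports. "The series", "measured", "known", "first", "only" and "open" are said of these compounds alone.

In an ADME assay on L02 cells (Homo sapiens) for cytotoxicity, read by MTT assay, with a stated time of 24 h (a lower number here means a stronger inhibitor, a higher number a weaker inhibitor), compound 1 `O=C1/C(=C/c2cccnc2)CN(S(=O)(=O)c2ccc(C(F)(F)F)cc2)C/C1=C\c1ccccc1F` gives 11300 nM, compound 2 `O=C1/C(=C/c2cccnc2)CN(S(=O)(=O)c2ccc(F)cc2)C/C1=C\c1ccccc1F` gives 15600 nM and compound 3 `O=C1/C(=C/c2ccncc2)CN(S(=O)(=O)c2ccc(F)cc2)C/C1=C\c1ccccc1F` gives 15600 nM. Compound 2 is level with compound 3 and within the scatter of compound 1. Compound 4 `O=C1/C(=C/c2cccnc2)CN(S(=O)(=O)c2ccc(F)cc2)C/C1=C\c1ccccc1C(F)(F)F` differs from compound 2 by one change: trifluoromethyl in place of fluoro on an aromatic carbon. This is trifluoromethyl in place of fluoro on an aromatic carbon, ortho to a large group. The closest measured precedent is the same exchange in the opposite sense at another place in the molecule, a 1.4-fold higher number from compound 1 to compound 2 (0.14 log units; within the scatter). The pyridinyl exchange, no change at the digits printed from compound 2 to compound 3 (within the scatter), bears on it only as a further sign of a flat series. No change beyond the scatter is expected, and the expected step is a 1.2-fold lower number from compound 2 to compound 4 (0.10 log units; within the scatter). Compound 4 is estimated at 12500 nM, with an expected range of 6500 nM to 24000 nM.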

Compound 4, half-maximal inhibitory concentration: 16100 nM
Beside the measured number, compound 4's estimate is 1.3-fold (0.11 log units) below it, within the range that was stated.
By their numbers in this assay, from the lowest: compounds 1, 2, 3 and 4 (each within the scatter of the next).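

In this assay the first change shown on this ring, 2-fluorophenyl to 2-(trifluoromethyl)phenyl, gives a 1.0-fold higher number from compound 2 to compound 4 (0.01 log units; within the scatter). The carbon ortho to a large group thus takes three more heavy atoms with no step beyond the scatter, so this exchange has now been read at a second place in the molecule. No measurement to hand accounts for this result.

The compounds shown carry only fluoro and trifluoromethyl at this carbon. As far as these compounds go, whether an amine or a carboxylic acid there would give a step beyond the scatter remains open.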